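The source may report more compounds than this note shows. Statements on the series, on what has been measured and on what is new or still open speak of the compounds shown alone.

Working notes on the series. Compound 3 `CC1=C(C(=O)Nc2ccc([N+](=O)[O-])cc2)C(c2cccc([N+](=O)[O-])c2)N=C(SCc2cccc(Cl)c2)N1` shares its core with compound 2 `CC1=C(C(=O)Nc2ccc([N+](=O)[O-])cc2)C(c2cccc([N+](=O)[O-])c2)N=C(SCc2ccccc2)N1` and compound 1 `CC1=C(C(=O)Nc2ccc([N+](=O)[O-])cc2)C(c2ccc(Br)cc2)N=C(SCc2ccc(Cl)cc2)N1`. In a functional assay on the whole organism (artery, strain albino) with Rattus norvegicus as the target, with a stated time of 600 min, at a dose of 10 mg/kg by the oral route (a higher number here means more inhibition at the dose given (going by the name of the read-out), a lower number less inhibition), compound 3 gives 19%, the lowest of the three numbers. For the measured compounds named here, compound 2 gives 27.2% in this assay, and the only single-point step so far, a number 8.2 percentage points lower from compound 2 to compound 3 (within the scatter), lies within the scatter. Going by the values given here, compound 1 gives 34.4% in this assay, a gap beyond the scatter from compound 3, but compound 1 differs from compound 3 in more than one place, so the two values stand on their own and no step is drawn between them.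

Compound 4 `CC1=C(C(=O)Nc2ccc([N+](=O)[O-])cc2)C(c2cccc([N+](=O)[O-])c2)N=C(SCc2ccc(Cl)cc2)N1` is not yet measured. The change 4-chlorophenyl in place of 3-chlorophenyl on a saturated chain carbon bound to a sulfur keeps the same atoms and alters only the (3-chlorobenzyl)sulfanyl to (4-chlorobenzyl)sulfanyl. Among the compounds with values here, no measured pair isolates 3-chlorophenyl against 4-chlorophenyl at this place; the step of a number 8.2 percentage points lower from compound 2 to compound 3 (within the scatter) touched the same group and stayed within the scatter. Compound 1 carries the entering 4-chlorobenzyl but with another group on the core, so its value only marks a range the series has reached. For compound 4 no step beyond the scatter is expected, a number 5 percentage points higher from compound 3 to compound 4 (within the scatter). Compound 4 is therefore estimated at 24%, with a range from 12% to 36%.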

Compound 4, a percentage reported as inhibition, in the whole organism at one dose (the size of the read-out at that dose, not a potency): 26.2%
Compound 4: the middle estimate sits 2.2 percentage points below what was measured; the measured number falls inside the stated range.
By their numbers in this assay, from the lowest: compounds 3, 4, 2 and 1 (each within the scatter of the next, the first and the last beyond it).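

In this assay, for the compounds shown here, 4-chlorophenyl in place of 3-chlorophenyl on a saturated chain carbon bound to a sulfur gives a number 7.2 percentage points higher from compound 3 to compound 4 (within the scatter) as the first pair to isolate this change, so the two chloro patterns are not told apart at this place. Chloro in place of hydrogen on an aromatic carbon now reads twice, as a number 8.2 percentage points lower from compound 2 to compound 3 (within the scatter) and as a number 1 percentage points lower from compound 2 to compound 4 (within the scatter) in this series, and neither chlorobenzyl separates from the plain benzyl of compound 2 in this assay. The other place gets its first single-place reading, with 3-nitrophenyl in place of 4-bromophenyl on a saturated ring carbon giving a number 8.2 percentage points lower from compound 1 to compound 4 (within the scatter) at this dose, and nothing at hand speaks to the reason for any of these numbers.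

Compound 1 and compound 3 stand beyond the scatter of each other but differ in two places, so neither place can be credited with that gap on its own. From the compounds shown here alone, whether an amine or a carboxylic acid on the benzyl ring, or a longer chain between the sulfur and the phenyl ring, would give a step beyond the scatter stays open.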